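The source may report more compounds than this note shows. Statements on the series, on what has been measured and on what is new or still open speak of the compounds shown alone.

Of the compounds shown here, three sharing one core have been measured in an assay for inhibition of kynurenine 3-monooxygenase (Homo sapiens), read by mass spectrometry, with a stated time of 1 h; on this read-out higher numbers stand for weaker inhibition and lower numbers for stronger inhibition. Compound 1 `CCc1cc2oc(=O)n(CCC(=O)O)c2cc1Cl` gives 10 nM. Compound 2 `O=C(O)CCn1c(=O)oc2cc(OCC3CC3)c(Cl)cc21` gives 10 nM. Compound 3 `COc1cc2oc(=O)n(CCC(=O)O)c2cc1Cl` gives 12.6 nM, a number that sits within the scatter of both others: a 1.3-fold higher number from compound 1 to compound 3 (0.10 log units; within the scatter) and a 1.3-fold higher number from compound 2 to compound 3 (0.10 log units; within the scatter), while the first two also show no change at the digits printed from compound 1 to compound 2 (within the scatter). Compound 4 `CCOc1cc2oc(=O)n(CCC(=O)O)c2cc1Cl` differs from compound 3 by methyl in place of hydrogen on a saturated chain carbon bound to an oxygen on an aromatic ring. The measured steps that bear on this change all read the same way: exchanging ethyl, methoxy and cyclopropylmethoxy on the aromatic carbon left the read-out within the scatter each time, so no step beyond the scatter is expected here either. The estimated step is a 1.1-fold lower number from compound 3 to compound 4 (0.06 log units; within the scatter). Compound 4 is therefore expected to give about 11 nM, with a range of 5 nM to 25 nM.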

Compound 4, half-maximal inhibitory concentration: 5.01 nM
Beside the measured number, compound 4's estimate is 2.2-fold (0.34 log units) above it, and the stated range covers the measured number.
By their numbers in this assay, from the lowest: compounds 4, 1, 2 and 3 (each within the scatter of the next, the first and the last beyond it).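

In this assay, going by these compounds alone, one added methyl on the saturated chain carbon bound to the oxygen gives the only step at this position that lies beyond the scatter (a 2.5-fold lower number from compound 3 to compound 4 (0.40 log units; beyond the scatter)). The other two steps stay within the scatter (a 2.0-fold lower number from compound 2 to compound 4 (0.30 log units; within the scatter); a 2.0-fold lower number from compound 1 to compound 4 (0.30 log units; within the scatter)), so ethoxy stands apart only from methoxy. Nothing measured here gives a reason for this step. From the compounds shown here alone, whether a longer chain such as propoxy would keep the lower number remains open. So does the effect of an amine on that aromatic carbon.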